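Same Oxygen Swap Repeated on a Longer Side Chain

The compounds below may be only part of what the source reports. "The series", "measured", "known", "first", "only" and "open" are said of these compounds alone.

Compound 1 `CC(C)=CCC1Cc2c(OCCCOc3ccc(Cl)cc3)cc(=O)n(CCCO)c2CC1(C)C` is the reference. In a functional assay on PANC-1 cells (Homo sapiens) for inhibition, read by MTT assay, with a stated time of 24 h, tested at 10 uM (a lower number here means less inhibition, a higher number more inhibition at the concentration tested (going by the name of the read-out)), compound 1 gives 0%. Compound 2 `COc1ccc(NC(=O)Oc2cc(=O)n(CCCO)c3c2CC(CC=C(C)C)C(C)(C)C3)cc1` differs from compound 1 by (4-methoxyphenyl)carbamoyl in place of 3-(4-chlorophenoxy)propyl on an oxygen on an aromatic ring, and in this assay compound 2 gives 0%, so that no change at the digits printed from compound 1 to compound 2 (within the scatter). Compound 3 `CC(C)=CCC/C(C)=C/CC1Cc2c(OCCCOc3ccc(Cl)cc3)cc(=O)n(CCCO)c2CC1(C)C` differs from compound 1 by 3-methylbut-2-en-1-yl in place of hydrogen on a saturated chain carbon bound to a double-bonded chain carbon, and in this assay compound 3 gives 0%, so that no change at the digits printed from compound 1 to compound 3 (within the scatter). All three measured compounds therefore sit at the same level in this assay.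

Compound 4 `COc1ccc(NC(=O)Oc2cc(=O)n(CCCO)c3c2CC(C/C=C(\C)CCC=C(C)C)C(C)(C)C3)cc1` is not yet measured. It differs from compound 3 by (4-methoxyphenyl)carbamoyl in place of 3-(4-chlorophenoxy)propyl on an oxygen on an aromatic ring. This is the same change as the one from compound 1 to compound 2, made at the same kind of place, but on the core of compound 3, which carries the longer chain described above. The step from compound 3 to compound 4 is expected to be no change at the digits printed from compound 3 to compound 4 (within the scatter), because no change at the digits printed from compound 1 to compound 2 (within the scatter) and the chain extension itself left the read-out where it was. Compound 4 is thus expected to give about 0% in this assay, with a likely range from 0% to 10%.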

Compound 4, a percentage reported as inhibition, at one concentration (the size of the read-out at that concentration, not a potency): 0%
The estimate for compound 4 equals the measured number at the digits printed; the range from low to high includes it.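

Putting (4-methoxyphenyl)carbamoyl in place of 3-(4-chlorophenoxy)propyl gives no change at the digits printed from compound 3 to compound 4 (within the scatter), and the swap behaves the same way on both cores: the same change on two cores in this assay, no change at the digits printed (within the scatter) from compound 1 to compound 2 and no change at the digits printed (within the scatter) from compound 3 to compound 4, 0 percentage points apart, within the scatter of two such steps. Adding 3-methylbut-2-en-1-yl gives no change at the digits printed from compound 2 to compound 4 (within the scatter), and this change also reads the same in both settings: the same change on two cores in this assay, no change at the digits printed (within the scatter) from compound 1 to compound 3 and no change at the digits printed (within the scatter) from compound 2 to compound 4, 0 percentage points apart, within the scatter of two such steps. This shows that neither change produces any measurable inhibition on these cores at the single concentration tested, but with all four compounds at the same reading, it does not show that the changes would carry over in the same way to a compound that does inhibit.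

The compounds shown leave open whether any member of this series can give a clear signal in this assay. From the compounds shown here alone, it also remains open whether an amine or a carboxylic acid, placed on the chain on an oxygen on an aromatic ring, would move the read-out.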